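Pyrimidine amide series: nitro to fluoro on the core

This account rests on a few compounds, and the source may have more. Where it says the series, first, only, none or still open, it means among the compounds named here.

Two compounds of the series have numbers in a functional assay on HeLa cells (Homo sapiens) for cytotoxicity, read by MTT assay, with a stated time of 48 h; a lower number here means a stronger inhibitor, a higher number a weaker inhibitor. Compound 1 `CN1CCC(NC(=O)c2ccc(Nc3ncc([N+](=O)[O-])c(NC4CCCC4)n3)cc2)CC1` gives 21700 nM in this assay, the higher of the two numbers; compound 2 `COc1cc(C(=O)NC2CCN(C)CC2)ccc1Nc1ncc(Br)c(NC2CCCC2)n1` gives 3500 nM in this assay, a lower number that lies beyond the scatter. Compound 2 differs from compound 1 in more than one place, so the comparison of the two values cannot be tied to a single change.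

Compound 3 `CN1CCC(NC(=O)c2ccc(Nc3ncc(F)c(NC4CCCC4)n3)cc2)CC1` has not yet been measured in this assay. Relative to compound 1 the change is fluoro in place of nitro on an aromatic carbon, all else being equal.

Among the compounds with values here, no single-change step is available for this position. Within the data shown here, the only guide is that compound 2, which carries a bromo at the same place on the core, gives 3500 nM in this assay, and that is a lower number than compound 1. A moderate move toward a lower number is therefore expected for compound 3, estimated as a 2.2-fold lower number from compound 1 to compound 3 (0.34 log units; beyond the scatter), though the size is uncertain and a step within the scatter is also possible. Compound 3 is expected to give about 10000 nM in this assay, with a range from 3000 nM to 35000 nM.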

Compound 3, half-maximal inhibitory concentration: 45500 nM
Compound 3: middle estimate off by 4.6-fold (0.66 log units), on the low side; measured number above the stated range.
By their numbers in this assay, from the lowest: compound 2; then compound 1; then compound 3.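

In this assay, within the data shown here, the nitro-to-fluoro swap gives the first single-change reading at this position of the shared core, a 2.1-fold higher number from compound 1 to compound 3 (0.32 log units; beyond the scatter), a modest step but one that shows the aromatic carbon ortho to the cyclopentylamino group is not indifferent to what it carries. Here the weaker inhibitor is the compound with fluoro, one heavy atom and no hydrogen-bond acceptors, in place of nitro, three heavy atoms and two hydrogen-bond acceptors, though a single pair sets no trend across substituents. No measurement at hand bears on what lies behind this step.

Compound 2 carries bromo at the same carbon but differs from compound 1 in more than one place, so the bromo cannot be ranked against nitro or fluoro on this evidence. Still open, going by these compounds, is where a nitrile, a trifluoromethyl group, an amine or plain hydrogen at this carbon would fall on the otherwise unchanged frame of compound 1, and whether the nitro-to-fluoro step would hold on a frame bearing the methoxy group of compound 2.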